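This account rests on a few compounds, and the source may have more. Where it says the series, first, only, none or still open, it means among the compounds named here.

Compound 1, `O=C(Nc1ccccc1O)C1CCc2ccccc2N1C(=O)c1ccc(Cl)cc1`, was tested in a functional assay on ACHN cells (Homo sapiens) for cytotoxicity, read by sulforhodamine B assay, with a stated time of 72 h (a higher number here means a weaker inhibitor of growth, a lower number a stronger inhibitor of growth), where compound 1 gives 19600 nM. For the measured compounds named here, compound 2, `O=C(Nc1ccc(C(F)(F)F)cc1)C1CCc2ccccc2N1`, gives 25000 nM in this assay, and that value and the one for compound 1 sit within the usual scatter of each other, so neither can be placed ahead of the other. Compound 3, `O=C(Nc1ccc(O)cc1)C1CCc2ccccc2N1`, reaches only a limit of the measurement, > 100000 nM. Going by the values given here, the single measured step between compounds that differ in one place runs from compound 2 to compound 3: an at least 4.0-fold higher number from compound 2 to compound 3 (0.60 log units; beyond the scatter), a change on an aromatic carbon, and its size is bounded only by the limit (the limit of > 100000 nM in this assay, at which 1 of the 3 values shown sits). Compound 4, `O=C(Nc1ccccc1O)C1CCc2ccccc2N1C(=O)c1cccc(Cl)c1`, differs from compound 1 in another place: 3-chlorophenyl in place of 4-chlorophenyl on a carbonyl carbon. Among the compounds with values here, no measured step touches the group on the carbonyl carbon, so there is nothing in these data to suggest a shift in either direction. The expectation for the step from compound 1 to compound 4 is a 1.0-fold higher number from compound 1 to compound 4 (0.01 log units; within the scatter), nothing beyond the scatter. Compound 4 is therefore estimated at 20000 nM, within 8000 nM to 50000 nM.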

Compound 4, concentration for 50% growth inhibition: 17200 nM
For compound 4 the middle estimate is 1.2-fold (0.07 log units) above the measured one, and the stated range covers the measured number.
By their numbers in this assay, from the lowest: compounds 4, 1 and 2 (each within the scatter of the next). At a limit, above all of these: compound 3.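

Putting 3-chlorophenyl in place of 4-chlorophenyl on the carbonyl carbon gives a 1.1-fold lower number from compound 1 to compound 4 (0.06 log units; within the scatter), so this assay does not separate the two compounds. This is the first step shown at this group, and it indicates that, for these two chlorine placements on the shared core of compound 1, the read-out stays within the usual scatter. Nothing shown here bears on why the two numbers agree so closely.

From the compounds shown here alone, both compounds carry chlorine on this phenyl ring, so it remains open whether a different group there, such as a methoxy group or an amine, would shift the number. Also open is what the whole group on the ring nitrogen contributes, as no step shown compares compounds with and without it.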